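A few compounds are considered here, and "the series" means these few. Any claim that something is new, unique, unknown or untested is made for them only; others in the source may bear on it.

Measured compounds in an ADME assay on NCM460 cells (Homo sapiens) for cytotoxicity, read by MTT assay, with a stated time of 72 h; on this read-out lower numbers stand for stronger inhibition and higher numbers for weaker inhibition:
compound 1 `CCCCCN1C(=O)C/C(=C\c2cccc(C(=O)Nc3ccc(C)cc3)c2)C1=O` gives > 100000 nM, a limit of the assay.
compound 2 `CCCCCN1C(=O)C/C(=C\c2cccc(C(=O)NCCCC)c2)C1=O` gives > 100000 nM, a limit of the assay.
compound 3 `CCCCCN1C(=O)C/C(=C\c2cccc(C(=O)Nc3ccc(OC)cc3)c2)C1=O` gives > 100000 nM, a limit of the assay.

For the measured compounds named here, compound 3 stands at the same limit as the other two measured compounds; the limit of > 100000 nM in this assay, at which 3 of the 3 values shown sit, marks where every value so far sits, so no order among the three can be read. The steps between the measured compounds are accordingly unreadable: a step that the two limits leave unreadable from compound 1 to compound 2, a step that the two limits leave unreadable from compound 1 to compound 3 and a step that the two limits leave unreadable from compound 2 to compound 3.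

Compound 4 `CCCCCN1C(=O)C/C(=C\c2cccc(C(=O)Nc3cccc(F)c3)c2)C1=O` is the next member of the series. Its change from compound 3 is 3-fluorophenyl in place of 4-methoxyphenyl on an amide-type nitrogen. Going by the values given here, none of the measured steps gives a readable size, so they bear on this change only in that every exchange tried so far, on the amide-type nitrogen and on the aromatic carbon alike, left the value at the limit. On that record no step beyond the scatter is expected for compound 4 in this assay, and the most probable outcome is that compound 4 also returns only a limit rather than a number. Expected is a step of a number no higher from compound 3 to compound 4 (the limit leaves the size open). Compound 4 is estimated at 100000 nM, with a range from 50000 nM to 200000 nM.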

Compound 4, half-maximal inhibitory concentration: > 100000 nM
Compound 4 ended at the assay's limit; the forecaster's own chance of this, stated with the estimate: 85%; the middle value sits exactly at the limit.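

In this assay, for the compounds shown here, compound 4 also returns only a limit, so no step from compound 1, compound 2 or compound 3 to compound 4 can be read: the limit of > 100000 nM in this assay, at which 4 of the 4 values shown sit. The compounds shown leave open how far apart these four lie, and whether any exchange on the amide-type nitrogen moves the value in this assay at all.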